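A few compounds are considered here, and "the series" means these few. Any claim that something is new, unique, unknown or untested is made for them only; others in the source may bear on it.

Going by the values given here, compound 1 `COc1cc(F)ccc1-c1cc2c(cn1)ncn2-c1ccc(OC(F)F)cc1` gives 93 nM in a functional assay on HL-60 cells (Homo sapiens) for activation, read by flow cytometry, with a stated time of 4 days (a lower number here means that less compound is needed, a higher number that more compound is needed for the effect), and is the lower of the two numbers measured so far. Compound 2 `CC(C)Oc1cc(F)ccc1-c1cc2c(cn1)ncn2-c1ccc(OC(F)F)cc1` gives 1100 nM. Among the compounds with values here, the single measured step, a 12-fold higher number from compound 1 to compound 2 (1.07 log units; beyond the scatter), shows a large loss when the group on the oxygen is enlarged. Compound 3 `Cc1ccc(-c2cc3c(cn2)ncn3-c2ccc(OC(F)F)cc2)c(C)c1` differs from compound 1 by 2,4-dimethylphenyl in place of 4-fluoro-2-methoxyphenyl on an aromatic carbon. This change removes the oxygen-bearing group entirely rather than enlarging it, so the measured step bears on it only indirectly. A modest shift is therefore expected: a 1.9-fold higher number from compound 1 to compound 3 (0.29 log units; within the scatter). Compound 3 is estimated at 180 nM, with a range from 50 nM to 650 nM.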

Compound 3, half-maximal effective concentration: 180 nM
For compound 3 middle estimate and measured number coincide at the digits printed; the range from low to high includes it.
By their numbers in this assay, from the lowest: compounds 1 and 3 (each within the scatter of the next); then compound 2.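

In this assay, 2,4-dimethylphenyl in place of 4-fluoro-2-methoxyphenyl on this aromatic carbon gives a 1.9-fold higher number from compound 1 to compound 3 (0.29 log units; within the scatter) with no oxygen or fluorine left on the ring. The hydrogen-bond acceptor of 4-fluoro-2-methoxyphenyl is therefore not required for a number in this range, and an all-carbon substituted phenyl ring is accepted at this position. No evidence on the cause of this result is at hand. Open, on these data alone, is how the methoxy and the fluorine each contribute when exchanged singly. Also open, as far as these compounds go, is how an amine or a carboxylic acid on this phenyl ring would read.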